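The source may hold more compounds than are shown below. What is called first, only, known or untested is meant among the compounds shown, and "the series" means these compounds.

Measured so far in an assay on cells for displacement of a labelled ligand from corticotropin-releasing factor receptor 1 (Homo sapiens), with a stated time of 100 min; a lower number here means a stronger inhibitor, a higher number a weaker inhibitor:
compound 1 `CCN(Cc1c(C(F)(F)F)nc2n(-c3c(C)cc(C)cc3C)c(Cl)cn12)CC1CC1`: compound 1 gives 9 nM
compound 2 `Cc1cc(C)c(-n2c(Cl)cn3c(CN(CCC4CC4)CCC(F)(F)F)c(C(F)(F)F)nc23)c(C)c1`: compound 2 gives 110 nM
compound 3 `Cc1cc(C)c(-n2c(Cl)cn3c(CN(CCC(F)(F)F)Cc4ccc(F)cc4)c(C(F)(F)F)nc23)c(C)c1`: compound 3 gives 34 nM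

Compound 1 holds the lowest number of the three; compound 3 stands nearest to it and compound 2 furthest, and both gaps lie beyond the scatter. Compound 4 `Cc1cc(C)c(-n2c(Cl)cn3c(CN(C)Cc4ccco4)c(C(F)(F)F)nc23)c(C)c1` is not yet measured. Against compound 1 the change is ((furan-2-yl)methyl)(methyl)amino in place of (cyclopropylmethyl)(ethyl)amino on a saturated chain carbon bound to an aromatic carbon.

Going by the values given here, the only measured step confined to the amine is a 3.2-fold lower number from compound 2 to compound 3 (0.51 log units; beyond the scatter), a modest move in favour of an aromatic ring carried on the chain carbon bound to the amine nitrogen. Among the compounds with values here, compound 2 and compound 3 each differ from compound 1 in both groups on that nitrogen, so no measured pair isolates the shift from ethyl to methyl, and none shows a furan ring. Taking the step from compound 2 to compound 3 as the nearest guide, the aromatic ring in compound 4 should not cost much, while the shorter methyl is unaccounted for. Compound 4 is therefore expected to sit somewhat above compound 1 in this assay, a step of a 2.8-fold higher number from compound 1 to compound 4 (0.44 log units; beyond the scatter), still clearly under compound 2. The estimate for compound 4 is 25 nM, with a range from 7 nM to 90 nM.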

Compound 4, inhibition constant: 180 nM
Estimate against measurement, compound 4: 7.2-fold (0.86 log units) below; measured number outside the range, above it.
By their numbers in this assay, from the lowest: compound 1; then compound 3; then compounds 2 and 4 (each within the scatter of the next).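

In this assay, ((furan-2-yl)methyl)(methyl)amino in place of (cyclopropylmethyl)(ethyl)amino on a saturated chain carbon bound to an aromatic carbon gives a 20-fold higher number from compound 1 to compound 4 (1.30 log units; beyond the scatter), a large step. This shows that the position is sensitive to the pair of groups on the amine nitrogen, and that the modest gain seen with the 4-fluorophenyl change does not make an aromatic ring on this nitrogen a safe choice in general. Nothing shown gives a reason for the size of this step.

The step combines two changes, so the share of the methyl and the share of the furan ring remain unseparated. The (cyclopropylmethyl)(methyl)amino and ((furan-2-yl)methyl)(ethyl)amino groups would divide it, and a (thiophen-2-yl)methyl group would test whether the ring oxygen matters.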